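From Methoxyphenyl to Difluorophenyl on the Aromatic Nitrogen

This account rests on a few compounds, and the source may have more. Where it says the series, first, only, none or still open, it means among the compounds named here.

Compound 2 `COc1cccc(-n2nc(-c3ccc(C(F)(F)F)cc3O)nc2-c2ccccc2O)c1` carries a 3-methoxyphenyl group on an aromatic nitrogen of the shared core. Among the measured compounds shown here, in a functional assay on PC-12 cells (Rattus norvegicus) for cytotoxicity, read by MTT assay, with stated times of 2 h and 24 h, tested at 5 uM (on this read-out lower numbers stand for a weaker effect and higher numbers for a stronger effect at the one concentration tested), compound 2 gives 96.8%, the highest of the two numbers measured so far. Compound 1 `COc1ccc(-n2nc(-c3ccc(C(F)(F)F)cc3O)nc2-c2ccccc2O)cc1`, which bears a 4-methoxyphenyl group instead, gives 86.6% in this assay, and the step of a number 10.2 percentage points higher from compound 1 to compound 2 (beyond the scatter) was modest. Compound 3 `Oc1cc(C(F)(F)F)ccc1-c1nc(-c2ccccc2O)n(-c2cc(F)cc(F)c2)n1` has not yet been measured. It differs from compound 2 by 3,5-difluorophenyl in place of 3-methoxyphenyl on an aromatic nitrogen. For the measured compounds named here, the single measured step only moves a methoxy group around the same ring and never exchanges the group for another, so no measured step bears directly on this change. Going by the values given here, the expected step is therefore a number 6.8 percentage points lower from compound 2 to compound 3 (within the scatter), none beyond the scatter, with a wide range because the only guidance the data give is the value of compound 2, 96.8%. Compound 3 is estimated at 90%, between 70% and 100%.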

Compound 3, a percentage reported as activity, at one concentration (the size of the read-out at that concentration, not a potency): 100%
The estimate for compound 3 lay 10 percentage points below the measured number; low and high end bracket the measured number.
By their numbers in this assay, from the lowest: compound 1; then compounds 2 and 3 (each within the scatter of the next).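

Among the compounds shown here, this is the first exchange of the group on the aromatic nitrogen rather than a shift of its methoxy group, and in this assay the change shows as a number 3.2 percentage points higher from compound 2 to compound 3 (within the scatter), so 3,5-difluorophenyl and 3-methoxyphenyl cannot be told apart here. Set against the 4-methoxyphenyl group, the same 3,5-difluorophenyl group gives a number 13.4 percentage points higher from compound 1 to compound 3 (beyond the scatter), which leaves compound 1 with the lowest number of the compounds shown. The data offer no explanation for why these groups read as they do.

The compounds shown leave open whether a plain phenyl group, or a phenyl ring carrying an amine or a carboxylic acid, would stay in this range. With one concentration behind each number, they also leave open how the compounds would compare at lower concentrations.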